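The source may report more compounds than this note shows. Statements on the series, on what has been measured and on what is new or still open speak of the compounds shown alone.

Within the data shown here, in an assay on HL-60 cells for agonist activity at vitamin D3 receptor (Homo sapiens), read by microscopy, with a stated time of 96 h (a higher number here means that more compound is needed for the effect, a lower number that less compound is needed), compound 2 `CCn1c(C(=O)NCC(OC)OC)ccc1C(CC)(CC)c1ccc(OCC(O)C(C)(C)C)c(C)c1` gives 150 nM, the lower of the two numbers known so far; compound 1 `CCn1c(C(=O)N(C)c2ccccc2)ccc1C(CC)(CC)c1ccc(OCC(=O)C(C)(C)C)c(C)c1`, in this assay, gives 18500 nM. Compound 3 `CCn1c(C(=O)N(C)c2ccccc2)ccc1C(CC)(CC)c1ccc(OCC(O)C(C)(C)C)c(C)c1` is not yet measured. It keeps the core of compound 2 but carries methyl(phenyl)amino in place of (2,2-dimethoxyethyl)amino on a carbonyl carbon, the same amide that compound 1 bears. Among the measured compounds shown here, compound 1 and compound 2 differ in two places, so no single step between them is known. A step upward, a 20-fold higher number from compound 2 to compound 3 (1.30 log units; beyond the scatter), is expected because compound 1 gives 18500 nM. The estimate for compound 3 is 3000 nM, within 400 nM to 20000 nM.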

Compound 3, half-maximal effective concentration: 6400 nM
The estimate for compound 3 lay 2.1-fold (0.33 log units) below the measured number; the measured number falls inside the stated range.
By their numbers in this assay, from the lowest: compound 2; then compound 3; then compound 1.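

In this assay the carbonyl carbon now has a reading in one place: methyl(phenyl)amino in place of (2,2-dimethoxyethyl)amino gives a 43-fold higher number from compound 2 to compound 3 (1.63 log units; beyond the scatter) and is the larger of the two steps. The change on the saturated chain carbon, 1-hydroxy-2,2-dimethylpropyl in place of (tert-butyl)carbonyl, gives a 2.9-fold lower number from compound 1 to compound 3 (0.46 log units; beyond the scatter) and is modest beside it. Nothing shown here explains either step.

As far as these compounds go, it remains open whether phenylamino, which keeps the amide hydrogen, or methylamino or morpholine on this carbonyl carbon would stay close to compound 2. From the compounds shown here alone, it is also open whether the ring or the lost dimethoxyethyl chain accounts for the step.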